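The source may report more compounds than this note shows. Statements on the series, on what has been measured and on what is new or still open speak of the compounds shown alone.

Measured compounds:
compound 1 `O=C(CN1CCC(Cc2ccccc2)CC1)Nc1ccc(C(=O)/C=C/c2cn(Cc3ccc(Br)cc3)nn2)cc1`, 54500 nM
compound 2 `CC(C)(C)OC(=O)N1CCN(CC(=O)Nc2ccc(C(=O)/C=C/c3cn(Cc4ccc(Br)cc4)nn3)cc2)CC1`, 31000 nM
compound 3 `CCCCCCCCCCn1cc(/C=C/C(=O)c2ccc(NC(=O)CN3CCC(Cc4ccccc4)CC3)cc2)nn1`, 55200 nM

In a functional assay on MCF7 cells (Homo sapiens) for inhibition, read by MTT assay (a lower number here means a stronger inhibitor, a higher number a weaker inhibitor), compound 1 and compound 3 differ in one place only, (nonyl in place of 4-bromophenyl on a saturated chain carbon bound to an aromatic nitrogen), and the step of a 1.0-fold higher number from compound 1 to compound 3 (0.01 log units; within the scatter) shows that this change left the number essentially unmoved. Compound 2 shares a different core; the difference between the two cores of compound 1 and compound 2 is not broken down here, and their values lie within the scatter of each other. The unmeasured compound 4 `CCCCCCCCCCn1cc(/C=C/C(=O)c2ccc(NC(=O)CN3CCN(C(=O)OC(C)(C)C)CC3)cc2)nn1` carries the same change on the core of compound 2, (nonyl in place of 4-bromophenyl on a saturated chain carbon bound to an aromatic nitrogen). Because the matching step a 1.0-fold higher number from compound 1 to compound 3 (0.01 log units; within the scatter) was flat, compound 4 is expected to stay near compound 2, with an expected step of no change at the digits printed from compound 2 to compound 4 (within the scatter). The estimate for compound 4 in this assay is 31000 nM, between 14000 nM and 68000 nM.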

Compound 4, half-maximal inhibitory concentration: 40000 nM
For compound 4 the middle estimate is 1.3-fold (0.11 log units) below the measured one; the range from low to high includes it.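

In this assay, putting nonyl in place of 4-bromophenyl on the core of compound 2 gives a 1.3-fold higher number from compound 2 to compound 4 (0.11 log units; within the scatter), so the two values lie within the scatter of each other. Set beside the earlier step, the change carries from one core to the other with no difference that can be read: the same change on two cores in this assay, a 1.0-fold higher number (0.01 log units; within the scatter) from compound 1 to compound 3 and a 1.3-fold higher number (0.11 log units; within the scatter) from compound 2 to compound 4, 1.3-fold (0.11 log units) apart, within the scatter of two such steps. This shows that the swap left the number essentially unmoved on both cores, but it does not show that the same would hold on any other core or in any other assay.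

The compounds shown leave open whether a shorter chain, or a chain ending in an amine or a carboxylic acid, would move the number in this assay.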